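Changing One Fluorinated Ring in a Close Analogue

The source may hold more compounds than are shown below. What is called first, only, known or untested is meant among the compounds shown, and "the series" means these compounds.

compound 1 `COc1ccc(C(=O)/C=C/c2ccccc2-c2ccc(F)nc2)cc1` | 8200 nM
compound 2 `COc1ccc(C(=O)/C=C/c2ccccc2-c2ccc(F)cc2)cc1OC` | 6600 nM

In a functional assay on HepG2 cells (Homo sapiens) for antiproliferative activity, read by sulforhodamine B assay, with a stated time of 48 h (a lower number here means a stronger inhibitor, a higher number a weaker inhibitor), compound 2 gives 6600 nM and compound 1 gives 8200 nM and these two values lie within the usual scatter of each other. Compound 3 `COc1ccc(C(=O)/C=C/c2ccccc2-c2ccc(F)nc2)cc1OC` has 6-fluoropyridin-3-yl in place of the 4-fluorophenyl of compound 2 on an aromatic carbon (6-fluoropyridin-3-yl in place of 4-fluorophenyl on an aromatic carbon). Within the data shown here, no measured pair shows this swap alone. Compound 1 also carries 6-fluoropyridin-3-yl, and compound 1 at 8200 nM gives the only hint. The estimated 1.1-fold higher number from compound 2 to compound 3 (0.03 log units; within the scatter) in this assay is expected to stay within the scatter, in neither direction. Compound 3 is expected at 7000 nM (estimated range 3200 nM to 15000 nM).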

Compound 3, half-maximal inhibitory concentration: 17000 nM
Beside the measured number, compound 3's estimate is 2.4-fold (0.39 log units) below it; measured number above the stated range.
By their numbers in this assay, from the lowest: compounds 2 and 1 (each within the scatter of the next); then compound 3.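

In this assay, the ring swap can now be read on its own: 6-fluoropyridin-3-yl in place of 4-fluorophenyl weakens the compound (a 2.6-fold higher number from compound 2 to compound 3 (0.41 log units; beyond the scatter)). With 6-fluoropyridin-3-yl kept, methoxy in place of hydrogen on an aromatic carbon also weakens it (a 2.1-fold higher number from compound 1 to compound 3 (0.32 log units; beyond the scatter)). Nothing available explains either step.

On these data alone, whether the methoxy step would be the same with 4-fluorophenyl remains open. So does what an amine or a carboxylic acid in place of the fluorine would do.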